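Amine substituent variation on the shared core

The source may hold more compounds than are shown below. What is called first, only, known or untested is meant among the compounds shown, and "the series" means these compounds.

For the measured compounds named here, compound 1 `CC(C)NCc1ccc(-c2c3ncn(CC4(O)CCN(Cc5ccc(-c6ccco6)cc5Cl)CC4)c(=O)c3nn2C)cc1` carries the higher of the two numbers measured so far in an assay on isolated protein for inhibition of ubiquitin carboxyl-terminal hydrolase 7 (Homo sapiens), with stated times of 30 min and 2 h (a lower number here means a stronger inhibitor, a higher number a weaker inhibitor), giving 29.1 nM; compound 2 `CCNCc1ccc(-c2c3ncn(CC4(O)CCN(Cc5ccc(-c6ccco6)cc5Cl)CC4)c(=O)c3nn2C)cc1` gives 15.2 nM, and the step of a 1.9-fold lower number from compound 1 to compound 2 (0.28 log units; within the scatter) stays within the scatter. Compound 3 `CCCNCc1ccc(-c2c3ncn(CC4(O)CCN(Cc5ccc(-c6ccco6)cc5Cl)CC4)c(=O)c3nn2C)cc1` differs from compound 1 by propyl in place of isopropyl on an amine nitrogen. Going by the values given here, the only measured step that bears on this position, a 1.9-fold lower number from compound 1 to compound 2 (0.28 log units; within the scatter), also changes the amine substituent and was small, so in this assay no step beyond the scatter is expected in either direction. Compound 3 is expected at 22 nM, in the range 10 nM to 50 nM, an estimated step of a 1.3-fold lower number from compound 1 to compound 3 (0.12 log units; within the scatter).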

Compound 3, half-maximal inhibitory concentration: 43.9 nM
Beside the measured number, compound 3's estimate is 2.0-fold (0.30 log units) below it; measured number inside the range.
By their numbers in this assay, from the lowest: compounds 2, 1 and 3 (each within the scatter of the next, the first and the last beyond it).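

In this assay, propyl in place of isopropyl on the amine nitrogen gives a 1.5-fold higher number from compound 1 to compound 3 (0.18 log units; within the scatter), so these two arrangements of the substituent are not told apart. Methyl in place of hydrogen on a saturated chain carbon, two bonds along the chain from the amine nitrogen, gives a 2.9-fold higher number from compound 2 to compound 3 (0.46 log units; beyond the scatter), the first step at this position to pass the scatter, though only modestly. No evidence on the cause of either step is available. As far as these compounds go, how a longer chain such as butyl, a cyclopropyl ring or a tertiary amine at this nitrogen would compare remains open. From the compounds shown here alone, whether the step seen with propyl holds for other groups on this nitrogen also remains open.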